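The compounds below may be only part of what the source reports. "The series", "measured", "known", "first", "only" and "open" are said of these compounds alone.

Compound 1, `FC(F)Oc1ccccc1C1Cc2nccn2C1`: in a functional assay on CHO cells for agonist activity at Alpha-1D adrenergic receptor (Homo sapiens), read by FLIPR and calcium flux (on this read-out higher numbers stand for an effect only at larger amounts of compound and lower numbers for an effect already at smaller amounts), compound 1 gives "not determined" (no result reported).
Compound 2, `COc1ccccc1C1CCc2nc[nH]c2C1`: in this assay compound 2 gives 3500 nM.
Compound 3, `COCc1ccccc1C1CCc2nc[nH]c2C1`: in this assay compound 3 gives > 10000 nM; > 10000 nM (2 entries), a limit of the assay rather than a number, recorded twice.

Compound 1 therefore stands nowhere on the numbers: no single half-maximal effective concentration is reported for it, and a further entry is likewise without a number. Compound 2 alone gives a measured value, and that is weak. Compound 3, which carries the same methoxymethyl group as compound 4 but on a different core, reaches only the limit of this assay in both of its entries.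

The step to compound 4, `COCc1ccccc1C1Cc2nccn2C1`, is the change (methoxymethyl in place of difluoromethoxy on an aromatic carbon). Going by the values given here, no measured step between two compounds describes this change, so its size cannot be read from the data; with compound 1 itself lacking a number, neither the direction nor the size of the step in this assay can be stated beyond saying that a weak result is to be expected. On the showing of compound 3 with its > 10000 nM; > 10000 nM (2 entries), compound 4 is estimated at 8000 nM in this assay, within a range from 2000 nM to 30000 nM, with a real chance that only a limit is reported.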

Compound 4, half-maximal effective concentration: > 10000 nM
Compound 4: only a limit was reported (the forecaster's own chance of this, stated with the estimate: 55%); middle value at least 1.2-fold (0.09 log units) away from the limit.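

In this assay compound 4 gives > 10000 nM, a limit of the assay and not a number. Going by these compounds alone, as compound 1 has no single number either, no step from compound 1 to compound 4 can be read. The compounds shown leave open how methoxymethyl and difluoromethoxy compare on the shared core in this assay.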